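The source may hold more compounds than are shown below. What is called first, only, known or untested is meant among the compounds shown, and "the series" means these compounds.

Working notes on the series. In a physicochemical assay for solubility, measured as kinetic solubility (on this read-out higher numbers stand for higher solubility and lower numbers for lower solubility), compound 1 `CCC/N=C1\S/C(=C\c2ccc(O)c(Cl)c2)C(=O)N1C1CCS(=O)(=O)CC1` gives 75000 nM. This lies within the scatter of compound 2 `CCC/N=C1\S/C(=C\c2ccc(O)cn2)C(=O)N1c1ccccc1C` at 110000 nM, while compound 3 `Cc1ccccc1N1C(=O)/C(=C/c2ccc(O)c(Cl)c2)S/C1=N\CCCF` at 20000 nM is lower, beyond the scatter.

The next step leads to compound 4 `CCC/N=C1\S/C(=C\c2ccc(O)c(Cl)c2)C(=O)N1c1ccccc1OC`, with 2-methoxyphenyl in place of 1,1-dioxothian-4-yl on an amide-type nitrogen in a ring. For the measured compounds named here, no measured pair isolates this change, so the expectation rests on three values alone.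

The closest guide is compound 3: compound 4 has a six-membered aromatic ring of carbon only at that nitrogen, and so does compound 3, which gives 20000 nM. Compound 2 also has such a ring but gives 110000 nM, so it goes against any reading of that ring as a mark of low numbers, and the range is kept wide.

A fall beyond the scatter is expected in this assay, with an estimated 3.0-fold lower number from compound 1 to compound 4 (0.48 log units; beyond the scatter). The expected value for compound 4 is 25000 nM, within an estimated range of 8000 nM to 70000 nM.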

Compound 4, solubility: 79000 nM
Compound 4: middle estimate off by 3.2-fold (0.50 log units), on the low side, and the stated range ends below it.
By their numbers in this assay, from the lowest: compound 3; then compounds 1, 4 and 2 (each within the scatter of the next).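

In this assay, for the compounds shown here, putting 2-methoxyphenyl in place of 1,1-dioxothian-4-yl gives a 1.1-fold higher number from compound 1 to compound 4 (0.02 log units; within the scatter), the first step that changes this one place alone. On an amide-type nitrogen in a ring, a six-membered aromatic ring of carbon only and a six-membered non-aromatic ring with a ring sulfur therefore cannot be told apart on this read-out, at least on the core of compound 1. No measured information is available to explain this outcome.

The compounds shown leave open whether a different kind of group on this nitrogen, such as an open-chain amine or a phenyl ring carrying a carboxylic acid, would also stay within the scatter of compound 1. They also leave open whether this swap gives the same result when a longer chain replaces the propyl group.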